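The compounds below may be only part of what the source reports. "The series", "measured", "known", "first", "only" and "open" are said of these compounds alone.

Working notes on the series. Compound 1 `CC(O)(C(=O)Nc1ccc(S(=O)(=O)c2ccc(F)cc2)cc1)C(F)(F)F` is the reference point: in a functional assay (Cavia porcellus) with sulfonylurea receptors; K-ATP channels (Homo sapiens) as the target (a higher number here means a weaker inhibitor, a lower number a stronger inhibitor), compound 1 gives 8600 nM. Going by the values given here, that is the only number the series has produced; the one further value is a limit rather than a number. Compound 2 `CC(O)(C(=O)Nc1ccc(S(=O)(=O)c2ccccc2)c(C(F)(F)F)c1)C(F)(F)F` is that case, and in this assay compound 2 gives > 30000 nM, which is a limit of the assay. What the data hold on the scale so far is the limit of > 30000 nM in this assay, at which 1 of the 2 values shown sits.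

Compound 3 `CC(O)(C(=O)Nc1ccc(S(=O)(=O)c2cncnc2)cc1)C(F)(F)F` has not yet been measured in this assay. Against compound 1 it differs at the aryl on the sulfonyl sulfur: pyrimidin-5-yl in place of 4-fluorophenyl on a sulfonyl sulfur. Among the compounds with values here, no measured pair shows a change of this kind, so no step size can be read from the data; the expectation rests on compound 1 alone. The step this estimate means, a 1.7-fold higher number from compound 1 to compound 3 (0.24 log units; within the scatter), is expected to run toward weaker inhibition, though it may well stay within the scatter of repeated measurements. Compound 3 is therefore estimated at 15000 nM in this assay, with a range from 6000 nM to 30000 nM.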

Compound 3, half-maximal inhibitory concentration: > 30000 nM
Compound 3: no number, only a limit (the forecaster's own chance of this, stated with the estimate: 35%); middle value at least 2.0-fold (0.30 log units) away from the limit.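

In this assay, the aryl on the sulfonyl sulfur is now the first place in the series with a readable step: pyrimidin-5-yl in place of 4-fluorophenyl gives an at least 3.4-fold higher number from compound 1 to compound 3 (0.54 log units; beyond the scatter). Compound 3 carries a limit of the assay and not a number, so this step sets only a floor on the change, and its true size cannot be read. The aryl on the sulfonyl sulfur is therefore not a silent place for this exchange, and the series now gathers at the weak end of the scale: the limit of > 30000 nM in this assay, at which 2 of the 3 values shown sit.

Going by these compounds alone, one exchange cannot separate the two ring nitrogens, the two hydrogen-bond acceptors and the loss of the fluorine from one another, and compound 2 differs from compound 1 in more than one place, so it offers no step to help. Going by these compounds, whether a single ring nitrogen, as in pyridin-3-yl, or another halogen, as in 4-chlorophenyl, would hold a measurable number at this sulfonyl sulfur remains open.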